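From Butyl(methyl)amino to Benzyl(methyl)amino: An Expected Small Step

This account rests on a few compounds, and the source may have more. Where it says the series, first, only, none or still open, it means among the compounds named here.

Measured in a functional assay on L1210 cells (Mus musculus) for antiproliferative activity, read by cell counting, with a stated time of 2 days; on this read-out higher numbers stand for weaker inhibition and lower numbers for stronger inhibition:
compound 1 `COc1cc(C(=O)c2sc(N(C)C)nc2N)cc(OC)c1OC`: 11000 nM
compound 2 `CCN(CC)c1nc(N)c(C(=O)c2cc(OC)c(OC)c(OC)c2)s1`: 62000 nM
compound 3 `CCCCN(C)c1nc(N)c(C(=O)c2cc(OC)c(OC)c(OC)c2)s1`: 53000 nM

Compound 3 stands level with compound 2, as the comparison shows a 1.2-fold lower number from compound 2 to compound 3 (0.07 log units; within the scatter). Only compound 1 stands apart from it, with a 4.8-fold higher number from compound 1 to compound 3 (0.68 log units; beyond the scatter). The diethylamino swap gives a similar picture, with a 5.6-fold higher number from compound 1 to compound 2 (0.75 log units; beyond the scatter).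

The next compound is compound 4 `COc1cc(C(=O)c2sc(N(C)Cc3ccccc3)nc2N)cc(OC)c1OC`. The change is phenyl in place of propyl on a saturated chain carbon bound to a nitrogen on an aromatic ring. In words, it is phenyl in place of propyl on a saturated chain carbon bound to a nitrogen on an aromatic ring, so butyl(methyl)amino becomes benzyl(methyl)amino.

Within the data shown here, no measured compound carries a phenyl at this place, so the steps bear on it only indirectly. Both steps away from dimethylamino were modest, and the two larger amino groups of compound 2 and compound 3 could not be told apart. On that showing, no step beyond the scatter is expected in this assay, although a move towards compound 1 remains possible. The estimated step is a 1.3-fold lower number from compound 3 to compound 4 (0.12 log units; within the scatter). For compound 4 the expected value is 40000 nM, with an estimated range from 12000 nM to 100000 nM.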

Compound 4, half-maximal inhibitory concentration: > 200000 nM
Compound 4: only a limit was reported; the forecaster's own chance of this, stated with the estimate: 10%; at least 5.0-fold (0.69 log units) between middle value and limit.
By their numbers in this assay, from the lowest: compound 1; then compounds 3 and 2 (each within the scatter of the next). At a limit, above all of these: compound 4.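

In this assay compound 4 is reported only as a limit, > 200000 nM, so every step to it gives only a minimum size. Unlike the change from diethylamino to butyl(methyl)amino, which stayed within the scatter, phenyl in place of propyl on a saturated chain carbon bound to a nitrogen on an aromatic ring produced a clear separation, with an at least 3.7-fold higher number from compound 3 to compound 4 (0.57 log units; beyond the scatter), and benzyl(methyl)amino in place of diethylamino gave an at least 3.2-fold higher number from compound 2 to compound 4 (0.50 log units; beyond the scatter). The earlier compounds showed only modest steps away from dimethylamino, whereas this position also tolerates a large step in the weaker direction, with an at least 18-fold higher number from compound 1 to compound 4 (1.25 log units; beyond the scatter), and the placing of compound 4 at the top of the series rests on a limit: the limit of > 200000 nM in this assay, at which 1 of the 4 values shown sits.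

The compounds shown leave open how far compound 4 actually lies from the others, and whether the loss follows the aromatic ring itself or the larger count of carbon atoms, which a cyclohexylmethyl(methyl)amino group at this place could help to separate. They also leave open whether a methylamino group or a plain amino group would go the other way from dimethylamino.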